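A few compounds are considered here, and "the series" means these few. Any claim that something is new, unique, unknown or untested is made for them only; others in the source may bear on it.

Compound 1, with the structure `COc1ncc(-c2ccc3c(c2)N(c2ccc(C)cc2)C(=O)CO3)cc1NS(=O)(=O)c1ccc(F)cc1`, gives 12900 nM in a functional assay on A-375 cells (Homo sapiens) for antiproliferative activity, read by MTT assay, with a stated time of 72 h; on this read-out lower numbers stand for stronger inhibition and higher numbers for weaker inhibition. Compound 2, with the structure `COc1ncc(-c2ccc3c(c2)N(c2ccc(F)cc2)C(=O)CO3)cc1NS(=O)(=O)c1ccc(F)cc1`, reaches only a limit of > 40000 nM in this assay. Among the compounds with values here, the single change between them, (fluoro in place of methyl on an aromatic carbon), thus produced an at least 3.1-fold higher number from compound 1 to compound 2 (0.49 log units; beyond the scatter). Compound 3, with the structure `Cc1ccc(N2C(=O)COc3ccc(-c4cccc(NS(=O)(=O)c5ccc(F)cc5)c4)cc32)cc1`, gives 36200 nM in this assay; how its core differs from that of compound 1 is not broken down here. Compound 4, with the structure `O=C1COc2ccc(-c3cccc(NS(=O)(=O)c4ccc(F)cc4)c3)cc2N1c1ccc(F)cc1`, carries the same change as before, (fluoro in place of methyl on an aromatic carbon), made on the core of compound 3. The step from compound 3 to compound 4 is expected to be a 2.5-fold higher number from compound 3 to compound 4 (0.40 log units; beyond the scatter), resting on the earlier at least 3.1-fold higher number from compound 1 to compound 2 (0.49 log units; beyond the scatter). Compound 4 is therefore estimated at 90000 nM in this assay, between 35000 nM and 250000 nM, and a limit rather than a number is likely because of the limit of > 40000 nM in this assay, at which 1 of the 3 values shown sits.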

Compound 4, half-maximal inhibitory concentration: > 40000 nM
Compound 4: a limit, no number; the forecaster's own chance of this, stated with the estimate: 80%; the middle value lies beyond the limit too.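

In this assay compound 4 reaches only a limit of > 40000 nM, not a number. Fluoro in place of methyl on the core of compound 3 thus gives an at least 1.1-fold higher number from compound 3 to compound 4 (0.04 log units; that floor lies within the scatter), so this step alone does not establish a loss of activity on that core, and the comparison between the two cores stays unresolved: the same change on two cores in this assay, an at least 3.1-fold higher number (0.49 log units; beyond the scatter) from compound 1 to compound 2 and an at least 1.1-fold higher number (0.04 log units; that floor lies within the scatter) from compound 3 to compound 4; the limit leaves it open whether they differ. The result does not contradict the direction seen on the core of compound 1, but it does not confirm that direction or show how large the change is on the core of compound 3.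

Going by these compounds, neither core has a fluoro compound with a measured number, so the true size of the step remains open on both. On these data alone, what a chloro group, a trifluoromethyl group or an amine would give in place of the methyl on either core also remains open.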